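Compound 4: methoxy in place of methyl

The source may report more compounds than this note shows. Statements on the series, on what has been measured and on what is new or still open speak of the compounds shown alone.

In an ADME assay on microsomes from liver (Rattus norvegicus) for metabolic stability, read by LC-MS, using NADPH, at 37 degrees C (a higher number here means that the compound lasts longer, a lower number that the compound disappears faster), compound 3 (`Cc1cccc(C)c1-c1nc(CN2CCC(C(=O)NCCCN3C[C@H](C)C[C@H](C)C3)CC2)c(C)o1`) gives 0.0517 h, within the scatter of compound 1 (`Cc1oc(-c2c(Cl)cccc2C(F)(F)F)nc1CN1CCC(C(=O)NCCCN2C[C@H](C)C[C@H](C)C2)CC1`) at 0.03 h. Compound 2 (`Cc1cccc(-c2nc(CN3CCC(C(=O)NCCCN4C[C@H](C)C[C@H](C)C4)CC3)c(C)o2)c1`) reads > 0.5 h, which is a limit of the assay. Compound 4 (`COc1cccc(C)c1-c1nc(CN2CCC(C(=O)NCCCN3C[C@H](C)C[C@H](C)C3)CC2)c(C)o1`) has methoxy in place of methyl on an aromatic carbon, ortho to a large group and meta to a methyl group: methoxy in place of methyl on an aromatic carbon.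

The closest measured swap is a 1.7-fold higher number from compound 1 to compound 3 (0.24 log units; within the scatter), within the scatter. The other two steps, an at least 16-fold higher number from compound 1 to compound 2 (1.22 log units; beyond the scatter) and an at least 9.6-fold lower number from compound 2 to compound 3 (0.98 log units; beyond the scatter), both involve the 3-methylphenyl of compound 2 and lie beyond it, so they bear less directly. The step expected in this assay is therefore none beyond the scatter: a 1.1-fold lower number from compound 3 to compound 4 (0.06 log units; within the scatter). For compound 4 the estimated half-life is 0.045 h, with an expected range of 0.02 h to 0.12 h.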

Compound 4, half-life: 0.0767 h
Estimate against measurement, compound 4: 1.7-fold (0.23 log units) below; low and high end bracket the measured number.
By their numbers in this assay, from the lowest: compounds 1, 3 and 4 (each within the scatter of the next, the first and the last beyond it). At a limit, above all of these: compound 2.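

Methoxy in place of methyl on this aromatic carbon leaves the half-life in this assay within the scatter: a 1.5-fold higher number from compound 3 to compound 4 (0.17 log units; within the scatter). Unlike 2,6-dimethylphenyl, 2-methoxy-6-methylphenyl separates from 2-chloro-6-(trifluoromethyl)phenyl, with a 2.6-fold higher number from compound 1 to compound 4 (0.41 log units; beyond the scatter), while the gap to 3-methylphenyl remains, with an at least 6.5-fold lower number from compound 2 to compound 4 (0.81 log units; beyond the scatter). The value of compound 2 is a limit, so that gap has no upper bound: the limit of > 0.5 h in this assay, at which 1 of the 4 values shown sits.

Open, from the compounds shown here alone, is how an amine or a carboxylic acid on this aromatic carbon would read. Also open, going by these compounds, is how a 3-methoxyphenyl group would compare with the 3-methylphenyl of compound 2.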